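Trading a Methylbenzyl for a Pivalate Ester

This account rests on a few compounds, and the source may have more. Where it says the series, first, only, none or still open, it means among the compounds named here.

Measured compounds:
Compound 1, `CC(C(=O)NCc1ccc(C(F)(F)F)nc1Nc1ccccc1)c1ccc(NS(C)(=O)=O)c(F)c1`: 1400 nM
Compound 2, `CC(C(=O)NCc1ccc(C(F)(F)F)nc1NCc1ccc(Cl)cc1)c1ccc(NS(C)(=O)=O)c(F)c1`: 414 nM
Compound 3, `Cc1ccc(CC2CCN(c3nc(C(F)(F)F)ccc3CNC(=O)C(C)c3ccc(NS(C)(=O)=O)c(F)c3)CC2)cc1`: 17 nM

In a functional assay on CHO-K1 cells for antagonist activity at transient receptor potential cation channel subfamily V member 1 (Homo sapiens), read by FLIPR (on this read-out lower numbers stand for stronger inhibition and higher numbers for weaker inhibition), compound 3 stands lowest of the three numbers; its nearest neighbour is compound 2, and compound 1 lies furthest away, both gaps beyond the usual scatter. Compound 4, `CC(C(=O)NCc1ccc(C(F)(F)F)nc1N1CCC(OC(=O)C(C)(C)C)CC1)c1ccc(NS(C)(=O)=O)c(F)c1`, has not yet been measured. It differs from compound 3 in one place: ((tert-butyl)carbonyl)oxy in place of 4-methylbenzyl on a saturated ring carbon. Going by the values given here, the only measured single step, a 3.4-fold lower number from compound 1 to compound 2 (0.53 log units; beyond the scatter), concerns a change on a nitrogen on an aromatic ring, not a change on the saturated ring, so it does not bear directly on this exchange. Among the compounds with values here, compounds 2 and 3 differ in more than one place, so their values say only that the saturated ring with its 4-methylbenzyl goes with a much lower number than the open chain of compound 2. Since the ring-bearing group that marks compound 3 is removed in compound 4 and a group without any ring enters, a weaker result than compound 3 is expected, though with considerable uncertainty, amounting to an expected step of a 5.9-fold higher number from compound 3 to compound 4 (0.77 log units; beyond the scatter). For compound 4 the estimate is 100 nM, expected between 25 nM and 500 nM.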

Compound 4, half-maximal inhibitory concentration: 45.2 nM
The estimate for compound 4 lay 2.2-fold (0.34 log units) above the measured number; low and high end bracket the measured number.
By their numbers in this assay, from the lowest: compound 3; then compound 4; then compound 2; then compound 1.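

In this assay, putting ((tert-butyl)carbonyl)oxy in place of 4-methylbenzyl on the saturated ring carbon gives a 2.7-fold higher number from compound 3 to compound 4 (0.42 log units; beyond the scatter), a modest step that is still beyond the usual scatter. Going by these compounds alone, this is the first direct reading at this position: the number rises, but only modestly, even though the group that enters has no ring and carries two hydrogen-bond acceptors, while the group that leaves has a six-membered aromatic ring and no acceptors, so on this one pair an aromatic ring on this carbon is not needed to keep the number close to that of compound 3. Nothing measured here explains why the step is this size.

The two groups differ in several ways at once, so this single pair cannot show whether the loss of the aromatic ring or the arrival of the ester accounts for the rise. It also leaves open how a plain tert-butyl, an amine or a carboxylic acid on the same saturated ring carbon would read in this assay, and such groups would help to separate these features.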